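The compounds below may be only part of what the source reports. "The series", "measured", "known", "first", "only" and "open" are said of these compounds alone.

The measured compounds:
compound 1 `Cc1ccc(OCCCON2C(N)=NC(N)=NC23CCOCC3)cc1`, 1060 nM
compound 2 `NC1=NC2(CCOCC2)N(OCCCOc2cccc(Cl)c2Cl)C(N)=N1`, 100 nM
compound 3 `NC1=NC2(CCOCC2)N(OCCCOc2ccc(Cl)cc2Cl)C(N)=N1`, 70 nM

In a functional assay on A549 cells (Homo sapiens) for antiproliferative activity, read by MTT assay, with a stated time of 72 h (on this read-out higher numbers stand for weaker inhibition and lower numbers for stronger inhibition), compound 3 gives the lowest number of the three, but its gap to compound 2 is small: a 1.4-fold lower number from compound 2 to compound 3 (0.15 log units; within the scatter). Against compound 1 the separation is clear, as a 15-fold lower number from compound 1 to compound 3 (1.18 log units; beyond the scatter) shows, and compound 2 stands apart from compound 1 in the same way, an 11-fold lower number from compound 1 to compound 2 (1.03 log units; beyond the scatter).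

Compound 4 `NC1=NC2(CCOCC2)N(OCCCOc2ccc(Br)cc2)C(N)=N1` has not been measured in this assay. It differs from compound 3 as follows: 4-bromophenyl in place of 2,4-dichlorophenyl on an oxygen on a saturated carbon.

Among the measured compounds shown here, two measured steps bear on this change. The steps from compound 1 to compounds 2 and 3 show that replacing 4-methylphenyl with a dichlorophenyl lowers the number by a large amount, while the step between the two dichlorophenyl compounds is within the scatter. Compound 4 keeps a single halogen on the ring and drops one chlorine, so an intermediate position between compound 1 and compound 3 is expected, with the number moving upward from compound 3: the expected step is a 4.3-fold higher number from compound 3 to compound 4 (0.63 log units; beyond the scatter). For compound 4 the estimated value in this assay is 300 nM, with a range from 100 nM to 900 nM.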

Compound 4, half-maximal inhibitory concentration: 280 nM
Beside the measured number, compound 4's estimate is 1.1-fold (0.03 log units) above it, and the stated range covers the measured number.
By their numbers in this assay, from the lowest: compounds 3 and 2 (each within the scatter of the next); then compound 4; then compound 1.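

In this assay, a single bromo in place of methyl on an aromatic carbon is already enough to separate the two rings (a 3.8-fold lower number from compound 1 to compound 4 (0.58 log units; beyond the scatter)), so this position does not need two chlorines for the number to fall. Among the compounds shown here, one bromine does not, however, match either dichlorophenyl ring, since the number rises on moving to 4-bromophenyl from 2,4-dichlorophenyl (a 4.0-fold higher number from compound 3 to compound 4 (0.60 log units; beyond the scatter)) and from 2,3-dichlorophenyl (a 2.8-fold higher number from compound 2 to compound 4 (0.45 log units; beyond the scatter)), which places compound 4 on a middle level that the earlier compounds did not show. Nothing available here accounts for these differences.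

The change from compound 3 to compound 4 alters both the kind of halogen and how many the ring carries, so the compounds shown do not tell these two apart, and a phenyl ring with a single chlorine would be needed to do so. Also open, on these data alone, is how the number would respond to a methoxy group on the ring, or to a longer chain joining the ring to the shared core.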